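A few compounds are considered here, and "the series" means these few. Any claim that something is new, unique, unknown or untested is made for them only; others in the source may bear on it.

Measured compounds in an ADME assay on HepG2 cells (Homo sapiens) for cytotoxicity, read by CellTiter-Glo and resazurin assay, with a stated time of 72 h; on this read-out higher numbers stand for an effect only at larger amounts of compound and lower numbers for an effect already at smaller amounts:

compound 1, `CC(C)N(Cc1cccc(OCCCCCC(=O)O)c1)C(=O)c1ccc(-c2ccoc2)cc1`: > 26000 nM
compound 2, `CC(C)N(Cc1cccc(OCCCCCC(=O)O)c1)C(=O)c1ccc(-c2ccc3c(c2)OCCO3)cc1`: > 21900 nM
compound 3, `CC(C)N(Cc1cccc(OCCCCCC(=O)O)c1)C(=O)c1ccc(-c2ccc3cc[nH]c3c2)cc1`: > 26000 nM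

Each of these three values is a limit of the assay, not a number. Compound 3 stands at the limit of > 26000 nM in this assay, at which 2 of the 3 values shown sit. Compound 2 stands at the limit of > 21900 nM in this assay, at which 1 of the 3 values shown sits. So compound 3 cannot be placed above or below its two neighbours; all three sit at the edge of what this assay can report.

Compound 4, `COc1ccc(F)c(-c2ccc(C(=O)N(Cc3cccc(OCCCCCC(=O)O)c3)C(C)C)cc2)c1`, has not yet been measured. It differs from compound 3 in one place: 2-fluoro-5-methoxyphenyl in place of 1H-indol-6-yl on an aromatic carbon. The three measured steps that bear on this change all swap the group at the same ring carbon: a step that the two limits leave unreadable from compound 1 to compound 2, a step that the two limits leave unreadable from compound 1 to compound 3 and a step that the two limits leave unreadable from compound 2 to compound 3. Each of them connects two limits and therefore has no readable size.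

The expected step is a step that the limit leaves unreadable from compound 3 to compound 4, that is, none beyond the scatter. Compound 4 is estimated at 30000 nM, within 10000 nM to 100000 nM, and it is most likely to come back once more as a limit rather than a number.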

Compound 4, half-maximal effective concentration: > 26000 nM
Compound 4 was reported as a limit; the forecaster's own chance of this, stated with the estimate: 85%; the middle value does not contradict the limit.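

Compound 4 came back as a limit, not a number, so the steps to it from compound 1, compound 2 and compound 3 cannot be read in this assay. The compounds shown leave open whether swapping these groups changes cytotoxicity at all.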